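Swapping the sulfur-borne aryl group in a benzamide series

The source may report more compounds than this note shows. Statements on the series, on what has been measured and on what is new or still open speak of the compounds shown alone.

Compound 3 `COc1ccc(SCc2ccc(C(=O)Nc3ccccc3N)cc2)cc1` carries the highest number of the three measured compounds in a functional assay on HCT-116 cells (Homo sapiens) for inhibition, read by CCK-8 assay, with a stated time of 72 h, tested at 8 uM (on this read-out higher numbers stand for more inhibition of growth at the one concentration tested and lower numbers for less inhibition of growth), giving 90.1%. Compound 1 `Nc1ccccc1NC(=O)/C=C/c1ccc(CSc2ccc(F)cc2)cc1` gives 20.2% in this assay, and compound 2 `Cc1cc(C)cc(SCc2ccc(/C=C/C(=O)Nc3ccccc3N)cc2)c1` gives 4.2%; compound 3 stands far above both, well beyond the scatter in each case. The unmeasured compound 4 `Nc1ccccc1NC(=O)c1ccc(CSc2cccc(F)c2)cc1` differs from compound 3 in a single place: 3-fluorophenyl in place of 4-methoxyphenyl on a sulfur.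

For the measured compounds named here, the only measured step that also changes the group on the sulfur is the one between compound 1 and compound 2, where the number fell a number 16 percentage points lower from compound 1 to compound 2 (beyond the scatter) in this assay. That step exchanges one aryl group for another on the same sulfur, though within a different core, and it points to a modest loss when a fluorophenyl group is replaced. Here the direction is reversed, a fluorophenyl enters, but the group it replaces carries the one acceptor that leaves. He therefore expects compound 4 to sit somewhat below compound 3, with a step of a number 25.1 percentage points lower from compound 3 to compound 4 (beyond the scatter) in this assay, and estimates 65% for compound 4, with a range from 35% to 90%.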

Compound 4, percent growth inhibition at one concentration: 81.4%
For compound 4 the middle estimate is 16.4 percentage points below the measured one, within the range that was stated.
By their numbers in this assay, from the lowest: compound 2; then compound 1; then compounds 4 and 3 (each within the scatter of the next).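

In this assay, replacing 4-methoxyphenyl with 3-fluorophenyl on a sulfur gives a number 8.7 percentage points lower from compound 3 to compound 4 (within the scatter), the first step shown at this position on the core of compound 3. For the compounds shown here, the one earlier step at this position, a number 16 percentage points lower from compound 1 to compound 2 (beyond the scatter), was on a different core and involved a different pair of aryl groups, so it said nothing about this exchange; here, 4-methoxyphenyl has a hydrogen-bond acceptor and 3-fluorophenyl has none, yet the two compounds are not separated beyond the scatter at the one concentration tested. Nothing shown here offers an explanation for this result.

The compounds shown leave open whether the tolerance seen with these two aryl groups extends to very different ones, such as a phenyl group carrying an amine or a carboxylic acid, or a longer chain in place of the aryl group on the sulfur. They also leave open whether compound 3 and compound 4 would separate in a full concentration series, since a single concentration gives only one point for each.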